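Moving the amino group on the phenyl ring

The compounds below may be only part of what the source reports. "The series", "measured", "known", "first", "only" and "open" are said of these compounds alone.

Compound 1 `CCOC(=O)CC1C(C(=O)OCC)=C(N)Oc2ccc(-c3ccc(F)cc3)cc21`: 72100 nM
Compound 2 `CCOC(=O)CC1C(C(=O)OCC)=C(N)Oc2ccc(-c3cccc(N)c3)cc21`: 20200 nM

In a functional assay on HL-60 cells (Homo sapiens) for cytotoxicity, read by CellTiter-Blue, with a stated time of 48 h (a lower number here means a stronger inhibitor, a higher number a weaker inhibitor), compound 2 holds the lower of the two numbers, 20200 nM. Compound 3 `CCOC(=O)CC1C(C(=O)OCC)=C(N)Oc2ccc(-c3ccc(N)cc3)cc21` has the same atoms joined differently: 4-aminophenyl in place of 3-aminophenyl on an aromatic carbon. Within the data shown here, only one measured step bears on this, the modest 3.6-fold lower number from compound 1 to compound 2 (0.55 log units; beyond the scatter), and it exchanged a different group. Among the measured compounds shown here, no measured pair tests the position of the amino group, so no firm direction can be expected, and a step within the scatter seems most likely. The estimated change is a 1.2-fold higher number from compound 2 to compound 3 (0.09 log units; within the scatter). The expected value for compound 3 is 25000 nM, with an estimated range from 10000 nM to 62000 nM.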

Compound 3, half-maximal inhibitory concentration: 22300 nM
Beside the measured number, compound 3's estimate is 1.1-fold (0.05 log units) above it; low and high end bracket the measured number.
By their numbers in this assay, from the lowest: compounds 2 and 3 (each within the scatter of the next); then compound 1.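

In this assay, 4-aminophenyl in place of 3-aminophenyl gives a 1.1-fold higher number from compound 2 to compound 3 (0.04 log units; within the scatter) so the two placements of the amino group cannot be told apart here. With the placement held the same, amino in place of fluoro gives a 3.2-fold lower number from compound 1 to compound 3 (0.51 log units; beyond the scatter) so the gain seen earlier does not depend on which of these two placements carries the amino group. No measurement here explains these numbers.

From the compounds shown here alone, it remains open whether a hydroxyl or a methoxy group on the phenyl ring would match the amino compounds. A dimethylamino group or a carboxylic acid at the same place is equally untested by the compounds shown.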